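The source may report more compounds than this note shows. Statements on the series, on what has been measured and on what is new or still open speak of the compounds shown alone.

Working notes on the series, stability read-out.

Compound 1 `Cc1csc2cc([C@H](C)Nc3ncnc(N)c3C#N)c(-c3ccccc3)c(=O)n12` and compound 2 `Cc1csc2cc([C@H](C)Nc3ncnc(N)c3C#N)c(Cc3cccc(CN(C)CC(C)C)c3)c(=O)n12` share one core. In an ADME assay on the whole organism (lung, Rattus norvegicus) for metabolic stability, read by LC-MS, with a stated time of 4 h (on this read-out higher numbers stand for a more stable compound and lower numbers for a less stable compound), compound 1 gives 0%. In this assay compound 2 gives 0%. Compound 2 thus stands level with compound 1 at the digits shown; the two values lie within the scatter of each other, so nothing can be said of a difference between them.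

Compound 3 `CNCc1cccc(Cc2c([C@H](C)Nc3ncnc(N)c3C#N)cc3scc(C)n3c2=O)c1` is not yet measured in this assay. It differs from compound 2 in one place: hydrogen in place of isobutyl on an amine nitrogen. Among the measured compounds shown here, no step between measured compounds that differ in a single place is available, so no measured step guides this change.

Given that compound 2 gives 0%, the step from compound 2 to compound 3 is expected to be small, at most a shift upward that stays within the scatter, a number 5 percentage points higher from compound 2 to compound 3 (within the scatter). For compound 3 the expected value in this assay is 5%, with a range from 0% to 20%.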

Compound 3, percent of the compound remaining in the lung assay: 2.5%
Beside the measured number, compound 3's estimate is 2.5 percentage points above it; the measured number falls inside the stated range.
By their numbers in the lung assay, from the lowest: compounds 1, 2 and 3 (each within the scatter of the next).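

In the lung assay this position takes a large change without the read-out leaving the scatter: hydrogen in place of isobutyl on an amine nitrogen gives one step (a number 2.5 percentage points higher from compound 2 to compound 3 (within the scatter)), and 3-((methylamino)methyl)benzyl in place of phenyl on an aromatic carbon gives another (a number 2.5 percentage points higher from compound 1 to compound 3 (within the scatter)). The same isobutyl change does register elsewhere: in a physicochemical assay for solubility (a lower number here means a less soluble compound, a higher number a more soluble compound), compound 2 gives 12000 nM and the step is beyond the scatter (an at least 83-fold higher number from compound 2 to compound 3 (1.92 log units; beyond the scatter)). In the physicochemical assay compound 3 gives > 1000000 nM, which is a limit of the assay and not a number.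

As far as these compounds go, whether a primary amine or a carboxylic acid in this place would lift the read-out in the lung assay clear of the scatter stays open. From the compounds shown here alone, how an ethyl or propyl chain on the amine nitrogen would fall in the physicochemical assay stays open too.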